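The compounds below may be only part of what the source reports. "The series", "measured", "known", "first", "only" and "open" are said of these compounds alone.

Measured in a functional assay on MGC-803 cells (Homo sapiens) for antiproliferative activity, read by MTT assay, with a stated time of 48 h; on this read-out lower numbers stand for stronger inhibition and higher numbers for weaker inhibition:
- Compound 1 `COc1ccc(CN(C(=O)CSc2nc3ccccc3s2)c2cc(OC)c(OC)c(OC)c2)cc1N=[N+]=[N-]`: 187 nM
- Compound 2 `COc1ccc(CN(C(=O)CSc2nc3ccccc3s2)c2cc(OC)c(OC)c(OC)c2)cc1Br`: 852 nM
- Compound 3 `COc1cc(N(Cc2ccc(F)cc2)C(=O)CSc2nc3ccccc3s2)cc(OC)c1OC`: > 80000 nM (a limit)

Compound 3 sits at > 80000 nM, which is a limit and not a number. Compound 4 `COc1cc(N(Cc2ccc(Br)cc2)C(=O)CSc2nc3ccccc3s2)cc(OC)c1OC` differs from it by bromo in place of fluoro on an aromatic carbon. Going by the values given here, no measured step makes this exchange directly. The closest are a 4.6-fold higher number from compound 1 to compound 2 (0.66 log units; beyond the scatter), and the two large steps of an at least 420-fold higher number from compound 1 to compound 3 (2.63 log units; beyond the scatter) and an at least 93-fold higher number from compound 2 to compound 3 (1.97 log units; beyond the scatter), but those large steps replace the whole substituted phenyl group. Since compound 4 keeps the 4-halophenyl pattern of compound 3, little recovery is expected in this assay, at most a small move towards lower numbers. The expected change is an at least 1.3-fold lower number from compound 3 to compound 4 (0.12 log units; that floor lies within the scatter). For compound 4 the estimate is 60000 nM, with an expected range of 12000 nM to 100000 nM.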

Compound 4, half-maximal inhibitory concentration: 48100 nM
Estimate against measurement, compound 4: 1.2-fold (0.10 log units) above, and the stated range covers the measured number.
By their numbers in this assay, from the lowest: compound 1; then compound 2; then compound 4. At a limit, above all of these: compound 3.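

Compound 3 stands at a limit, > 80000 nM, and not at a number. In this assay, bromo in place of fluoro on an aromatic carbon, para to a large group, gives a measured value, but the step reads only as an at least 1.6-fold lower number from compound 3 to compound 4 (0.22 log units; that floor lies within the scatter), so no gain beyond the scatter is shown. Bromo on its own does not bring back the activity of the earlier compounds: the result is a 56-fold higher number from compound 2 to compound 4 (1.75 log units; beyond the scatter) and a 260-fold higher number from compound 1 to compound 4 (2.41 log units; beyond the scatter).

The compounds shown leave open whether a methoxy group alone, without bromo or azido, would close that gap. They also leave open how an amine or a nitrile would read in place of the halogen.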